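Ethyl in place of the aryl group of compound 3

This account rests on a few compounds, and the source may have more. Where it says the series, first, only, none or still open, it means among the compounds named here.

In a functional assay on HUVEC cells (Homo sapiens) for antiproliferative activity, read by sulforhodamine B assay, with a stated time of 48 h (a lower number here means a stronger inhibitor, a higher number a weaker inhibitor), compound 3 `CN1CCC(COc2ccc3c(Nc4ccc(NC(=O)Nc5ccc(Cl)c(C(F)(F)F)c5)cc4)ncnc3c2)CC1` gives 92 nM, within the scatter of compound 1 `COc1cc2c(Nc3ccc(NC(=O)Nc4cccc(F)c4)c(F)c3)ncnc2cc1OCC1CCN(C)CC1` at 185 nM and of compound 2 `COc1cc2c(Nc3ccc(NC(=O)Nc4cccc(F)c4)cc3)ncnc2cc1OCC1CCN(C)CC1` at 179 nM. Compound 4 `CCNC(=O)Nc1ccc(Nc2ncnc3cc(OCC4CCN(C)CC4)ccc23)cc1` carries ethyl in place of 4-chloro-3-(trifluoromethyl)phenyl on an amide-type nitrogen. Among the measured compounds shown here, the only measured step, a 1.0-fold lower number from compound 1 to compound 2 (0.01 log units; within the scatter), is hydrogen in place of fluoro on an aromatic carbon. It lies within the scatter and touches a different place, so it says little here. Going by these compounds, all three measured compounds keep an aromatic ring on that nitrogen, and its loss is untested. The tentatively expected step is a 5.4-fold higher number from compound 3 to compound 4 (0.74 log units; beyond the scatter), towards a weaker inhibitor in this assay. For compound 4 the estimate is 500 nM, with an expected range of 130 nM to 2000 nM.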

Compound 4, half-maximal inhibitory concentration: 587 nM
Compound 4: middle estimate off by 1.2-fold (0.07 log units), on the low side; measured number inside the range.
By their numbers in this assay, from the lowest: compounds 3, 2 and 1 (each within the scatter of the next); then compound 4.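

In this assay, among the compounds shown here, the change at this amide-type nitrogen gives a 6.4-fold higher number from compound 3 to compound 4 (0.80 log units; beyond the scatter), the first step that lies beyond the scatter. Ethyl therefore retains measurable antiproliferative activity without an aromatic ring at this position, but the swap for 4-chloro-3-(trifluoromethyl)phenyl weakens it. No available evidence accounts for the size of this step.

For the compounds shown here, the single step cannot separate loss of the ring from loss of its chloro and trifluoromethyl substituents. Unsubstituted phenyl, or a longer chain such as butyl, on that nitrogen would address this.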